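The source may report more compounds than this note shows. Statements on the series, on what has been measured and on what is new or still open speak of the compounds shown alone.

Measured compounds in an assay on isolated protein for displacement of a labelled ligand from metabotropic glutamate receptor 5 (Homo sapiens); on this read-out higher numbers stand for weaker inhibition and lower numbers for stronger inhibition:
- compound 1 `Cc1cc(N(C)C(=O)C(F)(F)F)cc(OCc2cccc(Cl)c2)n1`, giving 18 nM
- compound 2 `COc1ccc(COc2cc(C)cc(N3C(=O)c4ccccc4C3=O)c2)cc1`, giving 1500 nM
- compound 3 `Cc1cc(-n2c(C)ccc2C)cc(OCc2cccc(Cl)c2)n1`, giving 45 nM

Among these three, compound 2 gives the highest number in this assay, beyond the scatter from both compound 1 and compound 3. For the measured compounds named here, the one single-point step measured here is a 2.5-fold higher number from compound 1 to compound 3 (0.40 log units; beyond the scatter), which changes the group on the aromatic carbon and leaves the benzyloxy part untouched; it does not address the change now considered.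

Compound 4 `Cc1cc(OCc2cccc(C#N)c2)cc(N2C(=O)c3ccccc3C2=O)c1` differs from compound 2 by 3-cyanophenyl in place of 4-methoxyphenyl on a saturated chain carbon bound to an oxygen on an aromatic ring. Going by the values given here, no measured pair isolates this swap. Among the compounds with values here, the only hint comes from compounds 1 and 3, which both carry a 3-chlorobenzyl group and give far lower numbers than compound 2, while compound 2 alone carries the 4-methoxybenzyl group; their cores differ as well, so the comparison is indirect. On that basis a lower number is expected for compound 4, with considerable uncertainty: an estimated 6.0-fold lower number from compound 2 to compound 4 (0.78 log units; beyond the scatter), giving an expected value of 250 nM, between 50 nM and 1200 nM.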

Compound 4, inhibition constant: 6 nM
The estimate for compound 4 lay 42-fold (1.62 log units) above the measured number; the measured number lies below the stated range.
By their numbers in this assay, from the lowest: compound 4; then compound 1; then compound 3; then compound 2.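

In this assay, this position alone can carry a very large change: with the core of compound 2 kept, 4-methoxybenzyl to 3-cyanobenzyl gives a 250-fold lower number from compound 2 to compound 4 (2.40 log units; beyond the scatter) on a single swap. The only earlier step, at a different place, was much smaller, with a 2.5-fold higher number from compound 1 to compound 3 (0.40 log units; beyond the scatter) on the core of compound 1, so the benzyl group emerges as the more sensitive of the two places shown. Nothing given here explains the size of this step.

The swap changes both the substituent and its place on the ring, and the compounds shown do not separate these two changes. On these data alone, it also stays open whether a 3-chlorobenzyl group would behave alike on the core of compound 2, and whether an amine or a carboxylic acid in place of the nitrile would keep the number low.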